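This account rests on a few compounds, and the source may have more. Where it says the series, first, only, none or still open, it means among the compounds named here.

Measured in a functional assay on NCI/ADR-RES cells (Homo sapiens) for cytotoxicity; a higher number here means a weaker inhibitor of growth, a lower number a stronger inhibitor of growth:
Compound 1 `COc1ccc(NS(=O)(=O)c2c(F)c(F)c(F)c(Br)c2F)cc1`: 190 nM
Compound 2 `COc1ccc(NS(=O)(=O)c2c(F)c(F)c(Br)c(F)c2F)cc1`: 21000 nM

Of the two, compound 2, at 21000 nM, has the higher number and is therefore the weaker inhibitor of growth. Compound 1, at 190 nM, lies lower by a gap well beyond the scatter of repeated measurements. Among the measured compounds shown here, no pair of measured compounds shows what a single change does here.

Attention now turns to compound 3 `COc1ccc(NS(=O)(=O)c2c(F)c(F)cc(F)c2F)cc1`, which differs from compound 2 in one place: hydrogen in place of bromo on an aromatic carbon. It has hydrogen in place of bromo on an aromatic carbon, para to a large group. For the measured compounds named here, no measured compound lacks the bromo group, so the expectation is loose, and it rests mainly on compound 2 at 21000 nM. In this assay, the estimated step, a 1.2-fold higher number from compound 2 to compound 3 (0.08 log units; within the scatter), is expected to stay within the scatter, with no firm direction. For compound 3 the expected value is 25000 nM, with an estimated range from 6000 nM to 100000 nM.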

Compound 3, concentration for 50% growth inhibition: > 50000 nM
Compound 3: a limit, no number; the forecaster's own chance of this, stated with the estimate: 25%; middle value at least 2.0-fold (0.30 log units) from the limit.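

In this assay compound 3 gives > 50000 nM, which is a limit of the assay and not a number. Among the compounds shown here, replacing the bromo group with hydrogen on this aromatic carbon, para to a large group, gives an at least 2.3-fold higher number from compound 2 to compound 3 (0.37 log units; beyond the scatter), the first single change that can be read, and it shows that the bromo group at this position is not interchangeable with hydrogen, even though compound 2 is itself a weak inhibitor of growth. The size of this step remains a lower bound, and the true loss may be much larger, because the step ends at a limit: the limit of > 50000 nM in this assay, at which 1 of the 3 values shown sits.

The compounds shown leave open whether another group on this carbon, such as chloro, methyl, methoxy or an amine, would give a lower number than compound 2 at 21000 nM. For the compounds shown here, they also leave open what a single change would do to compound 1, at 190 nM, whose bromo group stands elsewhere on the ring, as no measured compound differs from it in one place only.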